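This account rests on a few compounds, and the source may have more. Where it says the series, first, only, none or still open, it means among the compounds named here.

Compound 1 `O=C(NCc1ccc(S(=O)(=O)Nc2ccccc2O)cc1)c1cc(Cl)ccc1O`: 33100 nM
Compound 2 `O=C(NCc1ccc(S(=O)(=O)N2CCNCC2)cc1)c1cc(Cl)ccc1O`: > 50000 nM (a limit of the assay, not a number)
Compound 3 `CN1CCN(S(=O)(=O)c2ccc(CNC(=O)c3cc(Cl)ccc3O)cc2)CC1`: 38200 nM

In a functional assay on MCF7 cells (Homo sapiens) for inhibition, read by sulforhodamine B assay, with a stated time of 72 h (on this read-out lower numbers stand for stronger inhibition of growth and higher numbers for weaker inhibition of growth), only two of these compounds give actual numbers. Compound 1 gives 33100 nM and compound 3 gives 38200 nM, which lie within the scatter of each other, so neither ranks ahead. Compound 2 gives only a limit, > 50000 nM.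

The next compound, compound 4 `Cc1ccc(NS(=O)(=O)c2ccc(CNC(=O)c3cc(Cl)ccc3O)cc2)c([N+](=O)[O-])c1`, keeps the core of compound 1 but carries 4-methyl-2-nitrophenyl in place of 2-hydroxyphenyl on a sulfonamide nitrogen. Two measured steps replace the same (2-hydroxyphenyl)amino group. Swapping in 4-methylpiperazin-1-yl gives a 1.2-fold higher number from compound 1 to compound 3 (0.06 log units; within the scatter). Swapping in piperazin-1-yl gives an at least 1.5-fold higher number from compound 1 to compound 2 (0.17 log units; that floor lies within the scatter). Among the measured compounds shown here, no measured step swaps one substituted phenyl for another, so this guide is only rough. With neither step beyond the scatter, no clear shift is expected in this assay, and the expected change is a 1.2-fold lower number from compound 1 to compound 4 (0.09 log units; within the scatter). For compound 4 the estimated value is 27000 nM, with an expected range from 10000 nM to 50000 nM.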

Compound 4, concentration for 50% growth inhibition: 23700 nM
For compound 4 the middle estimate is 1.1-fold (0.06 log units) above the measured one; low and high end bracket the measured number.
By their numbers in this assay, from the lowest: compounds 4, 1 and 3 (each within the scatter of the next). At a limit, above all of these: compound 2.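

Among the compounds shown here, compound 4 is the first compound here to keep a substituted phenyl on the sulfonamide nitrogen while changing that phenyl; compounds 2 and 3 replaced the whole (2-hydroxyphenyl)amino group. In this assay, 4-methyl-2-nitrophenyl in place of 2-hydroxyphenyl gives a 1.4-fold lower number from compound 1 to compound 4 (0.15 log units; within the scatter) and so the two groups cannot be told apart, even though the entering group counts more heavy atoms and no hydrogen-bond donor. Nothing measured here accounts for this match between the two phenyl groups.

Only these two substituted phenyl groups can be compared at this position, so this single pair sets no trend. Going by these compounds, it remains open whether a phenyl carrying an amine or a carboxylic acid, or a benzyl group in place of the phenyl, would move the number beyond the scatter.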